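The source may report more compounds than this note shows. Statements on the series, on what has been measured and on what is new or still open speak of the compounds shown alone.

Measured compounds:
compound 1, `CCCCCCCCn1cc(/C=C/C(=O)c2ccc(NC(=O)CN3CCN(c4ccccc4F)CC3)cc2)nn1`: 60300 nM
compound 2, `O=C(CN1CCN(c2ccccc2F)CC1)Nc1ccc(C(=O)/C=C/c2cn(Cc3ccc(Br)cc3)nn2)cc1`: 12800 nM

Both compounds were tested in a functional assay on SK-N-SH cells (Homo sapiens) for inhibition, read by MTT assay; on this read-out lower numbers stand for stronger inhibition and higher numbers for weaker inhibition. Compound 1 gives the highest of the two numbers; its nearest neighbour is compound 2, and the step between them is a 4.7-fold lower number from compound 1 to compound 2 (0.67 log units; beyond the scatter). That step replaces a heptyl chain with 4-bromophenyl on a saturated chain carbon bound to an aromatic nitrogen, at one end of the shared core.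

Compound 3, `CCCCCCCCn1cc(/C=C/C(=O)c2ccc(NC(=O)CN3CCN(c4ccc([N+](=O)[O-])cc4)CC3)cc2)nn1`, has not yet been measured. It differs from compound 1 at the opposite end of the core: 4-nitrophenyl in place of 2-fluorophenyl on an amine nitrogen in a ring. For the measured compounds named here, no measured step touches this amine nitrogen in the six-membered non-aromatic ring, so the one known step, which sits elsewhere, does not bear on the change directly. With nothing measured at this place, the expectation for compound 3 in this assay is a step of no more than the usual scatter from the value of compound 1, in either direction, that is a 1.2-fold lower number from compound 1 to compound 3 (0.08 log units; within the scatter). Compound 3 is therefore estimated at 50000 nM, with a range from 15000 nM to 150000 nM.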

Compound 3, half-maximal inhibitory concentration: 51400 nM
The estimate for compound 3 lay 1.0-fold (0.01 log units) below the measured number; the range from low to high includes it.
By their numbers in this assay, from the lowest: compound 2; then compounds 3 and 1 (each within the scatter of the next).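

In this assay, for the compounds shown here, the first measurement at this amine nitrogen in the ring shows that 4-nitrophenyl in place of 2-fluorophenyl gives a 1.2-fold lower number from compound 1 to compound 3 (0.07 log units; within the scatter), so compound 1 and compound 3 cannot be told apart here. This holds even though 4-nitrophenyl brings hydrogen-bond acceptors and 2-fluorophenyl has none, so this one exchange of aromatic groups leaves no readable mark on the number, while the step at the other end of the core, a 4.7-fold lower number from compound 1 to compound 2 (0.67 log units; beyond the scatter), remains the only one beyond the scatter. No measured property or other supporting data bears on this result.

As far as these compounds go, this single pair carries the heptyl chain, so it remains open whether the same exchange would also leave the number unmoved with the 4-bromophenyl group of compound 2 at the other end of the core. The compounds shown also leave open how a group of a different kind on the amine nitrogen in the ring, such as a plain methyl, a benzyl or a phenyl bearing a carboxylic acid, would read in this assay.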